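The source may hold more compounds than are shown below. What is called first, only, known or untested is meant among the compounds shown, and "the series" means these compounds.

Among the measured compounds shown here, compound 3 `CSc1ccc(C2=NN(C(=S)Nc3ccccc3)C(c3ccc4c(c3)OCCO4)C2)cc1` gives 193000 nM in a functional assay on HCT-116 cells (Homo sapiens) for antiproliferative activity, read by MTT assay, with a stated time of 48 h (a lower number here means a stronger inhibitor of growth, a higher number a weaker inhibitor of growth), the highest of the three numbers measured so far. Compound 1 `Fc1ccc(C2=NN(C(=S)Nc3ccccc3)C(c3ccc4c(c3)OCCO4)C2)cc1` gives 61200 nM and compound 2 `FC(F)(F)c1ccc(C2=NN(C(=S)Nc3ccccc3)C(c3ccc4c(c3)OCCO4)C2)cc1` gives 112000 nM. Those three share one core and differ only in the substituent on the aromatic ring: a 3.2-fold higher number from compound 1 to compound 3 (0.50 log units; beyond the scatter), while a 1.7-fold higher number from compound 2 to compound 3 (0.24 log units; within the scatter) and a 1.8-fold higher number from compound 1 to compound 2 (0.26 log units; within the scatter). Compound 4 `COc1cccc(C2=NN(C(=S)Nc3ccccc3)C(c3ccc4c(c3)OCCO4)C2)c1` carries 3-methoxyphenyl in place of 4-(methylsulfanyl)phenyl on a carbon with a double bond to nitrogen. For the measured compounds named here, no measured step covers a methoxy group at that position, so the change is judged from the narrow spread of the first three values alone. Compound 4 is therefore expected to land close to compound 3, with a 1.6-fold lower number from compound 3 to compound 4 (0.21 log units; within the scatter) as the likely outcome. The estimate for compound 4 is 120000 nM, with a range from 40000 nM to 350000 nM.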

Compound 4, concentration for 50% growth inhibition: > 200000 nM
Compound 4 was reported as a limit; the forecaster's own chance of this, stated with the estimate: 10%; at least 1.6-fold (0.22 log units) between middle value and limit.
By their numbers in this assay, from the lowest: compounds 1, 2 and 3 (each within the scatter of the next, the first and the last beyond it). At a limit, above all of these: compound 4.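

In this assay, compound 4 is reported only as a limit, not as a number: the limit of > 200000 nM in this assay, at which 1 of the 4 values shown sits. Read as floors, an at least 1.0-fold higher number from compound 3 to compound 4 (0.01 log units; that floor lies within the scatter) and an at least 1.7-fold higher number from compound 2 to compound 4 (0.25 log units; that floor lies within the scatter) fix no order, while an at least 3.2-fold higher number from compound 1 to compound 4 (0.51 log units; beyond the scatter) does separate the pair. At this carbon, then, 3-methoxyphenyl gives no sign of stronger growth inhibition than the 4-substituted phenyl groups, and it does worse than 4-fluorophenyl.

Open, as far as these compounds go, is whether the methoxy group itself or its ring position matters, which 4-methoxyphenyl could test. Also open, from the compounds shown here alone, is how a phenyl bearing an amine or a carboxylic acid would behave here.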